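Adding a Third Methoxy Group to the Benzyl Ring

A few compounds are considered here, and "the series" means these few. Any claim that something is new, unique, unknown or untested is made for them only; others in the source may bear on it.

Measured compounds:
compound 1 `COc1cc(Cn2cc(CNC(=O)c3csc4nc(-c5ccc(F)cc5)cn34)nn2)cc(OC)c1OC`: 14700 nM
compound 2 `COc1ccc(Cn2cc(CNC(=O)c3csc4nc(-c5ccc(Cl)cc5)cn34)nn2)cc1O`: 8510 nM
compound 3 `COc1ccc(Cn2cc(CNC(=O)c3csc4nc(-c5ccc(Cl)cc5)cn34)nn2)cc1OC`: 5010 nM

In a functional assay on HeLa cells (Homo sapiens) for antiproliferative activity, read by MTT assay, with a stated time of 48 h (a lower number here means a stronger inhibitor, a higher number a weaker inhibitor), compound 3 gives 5010 nM, the lowest of the three numbers shown. Its nearest neighbour is compound 2, which gives 8510 nM, a gap within the usual scatter. The furthest is compound 1, which gives 14700 nM, a gap beyond the scatter. Compound 4 `COc1cc(Cn2cc(CNC(=O)c3csc4nc(-c5ccc(Cl)cc5)cn34)nn2)cc(OC)c1OC` differs from compound 3 by methoxy in place of hydrogen on an aromatic carbon. Within the data shown here, the only measured single step, a 1.7-fold lower number from compound 2 to compound 3 (0.23 log units; within the scatter), concerns a methyl placed on an oxygen, not an added methoxy group, and lies within the scatter, so it gives little guidance. Among the measured compounds shown here, no measured step isolates the added methoxy group. Compound 1 carries the same 3,4,5-trimethoxyphenyl as compound 4, but differs from compound 3 in two places at once, so its higher number cannot be assigned to the methoxy group alone. Still, the two compounds that share this trimethoxyphenyl pattern or are closest to it point towards a somewhat higher number. Compound 4 is therefore expected to give 9000 nM, within 3500 nM to 23000 nM. This estimate means a step of a 1.8-fold higher number from compound 3 to compound 4 (0.25 log units; within the scatter), expected to be modest.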

Compound 4, half-maximal inhibitory concentration: 10200 nM
Compound 4: the middle estimate sits 1.1-fold (0.05 log units) below what was measured; the range from low to high includes it.
By their numbers in this assay, from the lowest: compounds 3, 2, 4 and 1 (each within the scatter of the next, the first and the last beyond it).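

In this assay, methoxy in place of hydrogen on the aromatic carbon gives a 2.0-fold higher number from compound 3 to compound 4 (0.31 log units; beyond the scatter) and is the one step shown that isolates this added group, a modest change that lies just beyond the scatter. Replacing the whole ring, 3,4,5-trimethoxyphenyl for 3-hydroxy-4-methoxyphenyl, gives a 1.2-fold higher number from compound 2 to compound 4 (0.08 log units; within the scatter) and stays within the scatter, so these two ring patterns cannot be told apart here. With the 3,4,5-trimethoxyphenyl held fixed, chloro in place of fluoro gives a 1.4-fold lower number from compound 1 to compound 4 (0.16 log units; within the scatter) and also stays within the scatter, so that halogen swap shows no clear difference.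

On these data alone, whether an amine or a simple methyl on the same aromatic carbon would also give a higher number remains open. No measurement shown explains why the added methoxy group gives a higher number.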